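The source may report more compounds than this note shows. Statements on the series, on what has been measured and on what is new or still open speak of the compounds shown alone.

Series notes. Compound 1 `CC(C)CN1CCc2c(sc(NC(=O)Nc3ccc(Cl)cc3)c2C(N)=O)C1` and compound 3 `NC(=O)c1c(NC(=O)Nc2ccc(Cl)cc2)sc2c1CCN(CCCNC(=O)CCc1cccnc1)C2` share a core and the aryl urea; in a functional assay (strain AB) with Danio rerio as the target, read by microscopy, with a stated time of 1 h (a higher number here means that more compound is needed for the effect, a lower number that less compound is needed), compound 1 gives 4510 nM, and compound 3 gives 470 nM. Compound 2 `CCN1CCc2c(sc(NC(=O)Nc3ccc(Cl)cc3)c2C#N)C1` carries a nitrile in place of the carboxamide; in this assay compound 2 gives only a limit, > 25000 nM, which is the limit of > 25000 nM in this assay, at which 1 of the 3 values shown sits. Of the two numbers shown, compound 3 stands lowest, with compound 1 well beyond the scatter above it. Compound 4 `CC(C)(C)OC(=O)CCCCN1CCc2c(sc(NC(=O)Nc3ccc(Cl)cc3)c2C(N)=O)C1` differs from compound 3 only at the chain on the ring amine: (tert-butoxycarbonyl)methyl in place of ((2-(pyridin-3-yl)ethyl)carbonyl)amino on a saturated chain carbon, three bonds along the chain from an amine nitrogen in a ring. Among the compounds with values here, no measured step covers this change. Compound 1 shows that a plain chain on the same nitrogen gives a higher number, so a step upward beyond the scatter is expected, a 3.2-fold higher number from compound 3 to compound 4 (0.50 log units; beyond the scatter), placing compound 4 at an estimated 1500 nM (500 nM to 5000 nM).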

Compound 4, half-maximal effective concentration: 710 nM
Beside the measured number, compound 4's estimate is 2.1-fold (0.32 log units) above it; the range from low to high includes it.
By their numbers in this assay, from the lowest: compounds 3 and 4 (each within the scatter of the next); then compound 1. At a limit, above all of these: compound 2.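

In this assay, the pyridine ring is not needed to hold the number at this position: replacing ((2-(pyridin-3-yl)ethyl)carbonyl)amino with (tert-butoxycarbonyl)methyl leaves it within the scatter (a 1.5-fold higher number from compound 3 to compound 4 (0.18 log units; within the scatter)). The ringless 3-(tert-butoxycarbonyl)propyl chain still separates clearly from the isopropyl end of compound 1 (a 6.4-fold lower number from compound 1 to compound 4 (0.80 log units; beyond the scatter)), so the lower number is not tied to the pyridine-bearing group. Nothing measured here gives a cause for either step. Open, on these data alone, is whether a carboxylic acid or a primary amine at the chain end, or a longer chain, keeps this level.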